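This account rests on a few compounds, and the source may have more. Where it says the series, first, only, none or still open, it means among the compounds named here.

Measured compounds in a functional assay on MCF7 cells (Homo sapiens) for inhibition, read by MTT assay, with a stated time of 72 h; a higher number here means a weaker inhibitor, a lower number a stronger inhibitor:
Compound 1 `Cc1ccc(Nc2nc(SCc3cn(CC(=O)NC(=O)Nc4ccccn4)nn3)nc(-c3ccc(C(C)C)cc3)c2C#N)cc1`: > 64000 nM, which is a limit of the assay rather than a number.
Compound 2 `Cc1ccc(Nc2nc(SCc3cn(CC(=O)NC(=O)Nc4ccccn4)nn3)nc(-c3ccc(C)cc3)c2C#N)cc1`: 39600 nM.
Compound 3 `Cc1ccc(Nc2nc(SCc3cn(CC(=O)NC(=O)Nc4ccccn4)nn3)nc(-c3ccc(Br)cc3)c2C#N)cc1`: 14400 nM.

Compound 3 gives the lowest of the two numbers, with compound 2 nearest. Compound 1 sits at the limit of > 64000 nM in this assay, at which 1 of the 3 values shown sits.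

Compound 4 `Cc1ccc(Nc2nc(SCc3cn(CC(=O)NC(=O)Nc4ccccn4)nn3)nc(-c3ccccc3)c2C#N)cc1` has not yet been measured; it differs from compound 3 by hydrogen in place of bromo on an aromatic carbon. Among the measured compounds shown here, the steps that bear on this change are a 2.8-fold lower number from compound 2 to compound 3 (0.44 log units; beyond the scatter) and an at least 4.4-fold lower number from compound 1 to compound 3 (0.64 log units; beyond the scatter); in both, bromo replaced a carbon group and the number fell. Taking the bromo away altogether is therefore expected to raise the number, by roughly a 2.8-fold higher number from compound 3 to compound 4 (0.44 log units; beyond the scatter). Compound 4 is accordingly estimated at 40000 nM, within a range from 15000 nM to 64000 nM.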

Compound 4, half-maximal inhibitory concentration: > 64000 nM
Compound 4: no number, only a limit; the forecaster's own chance of this, stated with the estimate: 30%; middle value at least 1.6-fold (0.20 log units) from the limit.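

In this assay, among the compounds shown here, the earlier steps compared the bromo only with carbon groups, and now removing it altogether also gives a clear change: an at least 4.4-fold higher number from compound 3 to compound 4 (0.64 log units; beyond the scatter). Against the methyl, hydrogen gives an at least 1.6-fold higher number from compound 2 to compound 4 (0.20 log units; that floor lies within the scatter), so no order between these two can be claimed. The step between compound 1 and compound 4 cannot be read, since each gives only a limit: the limit of > 64000 nM in this assay, at which 2 of the 4 values shown sit.

From the compounds shown here alone, whether the advantage is particular to bromo remains open, as no other halogen, such as chloro or iodo, appears at this place on the ring. A methoxy group or an amine there is also untested in the compounds shown.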